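This account rests on a few compounds, and the source may have more. Where it says the series, first, only, none or still open, it means among the compounds named here.

Measured so far in an ADME assay on microsomes from liver (Mus musculus) for metabolic stability, read by LC-MS, using NADPH, with stated times of 10 min and 30 min, tested at 1 uM; a higher number here means faster removal of the compound, a lower number slower removal
- compound 1 `COC(=O)C1=C(CN2CCC(O)CC2)NC(c2nccs2)=NC1(C)c1ccc(F)cc1` gives 81 mL/min/kg
- compound 2 `COC(=O)C1=C(CN2CCC(F)(F)CC2)NC(c2nccs2)=NC1(C)c1ccc(F)cc1` gives 88 mL/min/kg
- compound 3 `COC(=O)C1=C(CN2CCC(C(F)(F)F)C2)NC(c2nccs2)=NC1(C)c1ccc(F)cc1` gives 88 mL/min/kg

Compound 3 stands at 88 mL/min/kg in this assay and matches compound 2 at the digits shown. It also lies within the scatter of compound 1 .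

The next step leads to compound 4 `COC(=O)C1=C(Cn2ccnc2)NC(c2nccs2)=NC1(C)c1ccc(F)cc1` and exchanges one group for another: 1H-imidazol-1-yl in place of 3-(trifluoromethyl)pyrrolidin-1-yl on a saturated chain carbon bound to a double-bonded ring carbon.

The measured swaps at this same place bear on it. They are a 1.1-fold higher number from compound 1 to compound 2 (0.04 log units; within the scatter) and a 1.1-fold higher number from compound 1 to compound 3 (0.04 log units; within the scatter) and no change at the digits printed from compound 2 to compound 3 (within the scatter) in size, all small. Within the data shown here, none of the measured compounds carries an aromatic ring at this place, so the range is kept wide.

No step beyond the scatter is expected in this assay, and a direction can only be tentative. The estimated change is a 1.2-fold lower number from compound 3 to compound 4 (0.07 log units; within the scatter) and no more than that is expected. Compound 4 is estimated at 75 mL/min/kg with an expected range from 45 mL/min/kg to 100 mL/min/kg in this read-out.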

Compound 4, clearance: 69 mL/min/kg
For compound 4 the middle estimate is 1.1-fold (0.04 log units) above the measured one; the range from low to high includes it.
By their numbers in this assay, from the lowest: compounds 4, 1, 2 and 3 (each within the scatter of the next).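

In this assay, the 1H-imidazol-1-yl of compound 4 brings the first aromatic ring to this place, and the read-out gives a 1.3-fold lower number from compound 3 to compound 4 (0.11 log units; within the scatter), a 1.3-fold lower number from compound 2 to compound 4 (0.11 log units; within the scatter) and a 1.2-fold lower number from compound 1 to compound 4 (0.07 log units; within the scatter). The hydroxy, fluorinated and aromatic groups shown at this place therefore give no step beyond the scatter, and this holds for all four compounds. Nothing available here accounts for this lack of separation.

Going by these compounds, whether any group at this place can shift the number beyond the scatter remains open, for example a carboxylic acid, a primary amide or a longer chain carrying the imidazole. Also open, on these data alone, is whether a change elsewhere on the shared core, such as an amide in place of the methyl ester, would alter the read-out when this group does not.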